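Swapping 4-isopropylphenyl for 3-chlorophenyl on a shared core

The source may report more compounds than this note shows. Statements on the series, on what has been measured and on what is new or still open speak of the compounds shown alone.

Values measured in a functional assay on MCF7 cells (Homo sapiens) for cytotoxicity, read by MTT assay, with a stated time of 48 h (on this read-out lower numbers stand for stronger inhibition and higher numbers for weaker inhibition), so far:
- compound 1 `O=C1CS/C(=N/c2ccccc2)N1Cc1ccncc1` gives 65800 nM
- compound 2 `CN(C)c1ccc(/C=C2/S/C(=N/c3ccccc3)N(Cc3ccncc3)C2=O)cc1` gives 76300 nM
- compound 3 `CC(C)c1ccc(/C=C2/S/C(=N/c3ccccc3)N(Cc3ccncc3)C2=O)cc1` gives 53300 nM

In this assay compound 3 gives 53300 nM and sits within the usual scatter of both compound 1 and compound 2, so these values do not separate it from either. Compound 4 `O=C1/C(=C\c2cccc(Cl)c2)S/C(=N/c2ccccc2)N1Cc1ccncc1` has not yet been measured. It carries 3-chlorophenyl in place of 4-isopropylphenyl on a double-bonded chain carbon bound to a double-bonded ring carbon and otherwise matches compound 3.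

Going by the values given here, the one measured step on this aromatic group is a 1.4-fold lower number from compound 2 to compound 3 (0.16 log units; within the scatter) with isopropyl in place of dimethylamino on an aromatic carbon, and it stays within the scatter. Among the compounds with values here, no measured compound carries chlorine, so the data give no direct guide to that group. A step beyond the scatter is not expected in this assay in either direction. The expected change is a 1.1-fold lower number from compound 3 to compound 4 (0.03 log units; within the scatter) by this estimate. Compound 4 is expected at 50000 nM with an estimated range of 24000 nM to 95000 nM in this read-out.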

Compound 4, half-maximal inhibitory concentration: 29800 nM
Compound 4: the middle estimate sits 1.7-fold (0.22 log units) above what was measured, and the stated range covers the measured number.
By their numbers in this assay, from the lowest: compounds 4, 3, 1 and 2 (each within the scatter of the next, the first and the last beyond it).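

In this assay, replacing 4-isopropylphenyl with 3-chlorophenyl on the double-bonded chain carbon gives a 1.8-fold lower number from compound 3 to compound 4 (0.25 log units; within the scatter) and cannot be told apart from ordinary variation between repeats. Going by these compounds alone, the comparison with the 4-(dimethylamino)phenyl group is clearer: it gives a 2.6-fold lower number from compound 2 to compound 4 (0.41 log units; beyond the scatter), the first step at this position to pass beyond the scatter, and so shows that changing this aromatic group can move the number, if only modestly. No measurement available here explains this shift.

The compounds shown leave open whether a group of another kind at this position, such as a carboxylic acid or a nitrile on the phenyl ring, would produce a larger step. They also leave open whether a step of similar size would appear with the rest of the shared core changed.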